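The source may report more compounds than this note shows. Statements on the series, on what has been measured and on what is new or still open speak of the compounds shown alone.

Compound 1, `C[C@]1(CN2CCc3nc(-c4ccc(OC(F)(F)F)cc4)ccc3C2)Cn2cc([N+](=O)[O-])nc2O1`, carries the shared core with a 4-(trifluoromethoxy)phenyl group, and in an ADME assay on Vero cells (Chlorocebus sabaeus) for cytotoxicity, read by MTT assay, with a stated time of 72 h (on this read-out lower numbers stand for higher toxicity in this test and higher numbers for lower toxicity in this test), compound 1 stands without a number: its entry reads "not determined" (no result reported). Compound 2, `C[C@]1(CN2CCc3nc(N4CCC(F)(F)CC4)ccc3C2)Cn2cc([N+](=O)[O-])nc2O1`, is in the same position, with an entry of "not determined" (no result reported) in this assay. Only compound 3, `C[C@]1(CN2CCc3nc(-c4cc(F)cc(F)c4)ccc3C2)Cn2cc([N+](=O)[O-])nc2O1`, has a reported result; in this assay compound 3 gives > 32 ug/mL, which is a limit of the assay rather than a number. This is the limit of > 32 ug/mL in this assay, at which 1 of the 3 values shown sits, so the one reported result shows no toxicity within the range tested.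

Compound 4, `C[C@]1(CN2CCc3nc(-c4ccc(F)c(Cl)c4)ccc3C2)Cn2cc([N+](=O)[O-])nc2O1`, differs from compound 1 by 3-chloro-4-fluorophenyl in place of 4-(trifluoromethoxy)phenyl on an aromatic carbon. Going by the values given here, since compound 1 has no number in this assay, no step can be measured against it, and the size expected from compound 1 to compound 4 in this assay is none that could be told apart from the scatter. Compound 4 is therefore expected to give about 32 ug/mL in this assay, estimated to lie between 12 ug/mL and 80 ug/mL, most likely reported as a limit like that of compound 3.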

Compound 4, half-maximal cytotoxic concentration: > 32 ug/mL
Compound 4 ended at the assay's limit (the forecaster's own chance of this, stated with the estimate: 60%); the middle value lies on the limit itself.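

Compound 3 and compound 4 both stand at a limit of this assay rather than at a number, so no step between them can be read: the limit of > 32 ug/mL in this assay, at which 2 of the 4 values shown sit.

The compounds shown leave open how far apart compound 3 and compound 4 truly lie, and where any compound shown would reach a measurable cytotoxic concentration.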